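Tert-Butoxy in Place of Benzyloxy on a Sodium/Hydrogen Exchanger Inhibitor

This account rests on a few compounds, and the source may have more. Where it says the series, first, only, none or still open, it means among the compounds named here.

Compound 1 `CCCCCc1cc(C)c(C(=O)N=C(N)N)cc1S(C)(=O)=O`: 27 nM
Compound 2 `Cc1cc(OCc2ccccc2)c(S(C)(=O)=O)cc1C(=O)N=C(N)N`: 28 nM

Compound 2 gives the higher of the two numbers in a functional assay for inhibition of sodium/hydrogen exchanger (Oryctolagus cuniculus) (a lower number here means a stronger inhibitor, a higher number a weaker inhibitor), though its step from compound 1 is small: a 1.0-fold higher number from compound 1 to compound 2 (0.02 log units; within the scatter). Compound 3 `Cc1cc(OC(C)(C)C)c(S(C)(=O)=O)cc1C(=O)N=C(N)N` carries a (tert-butyl in place of benzyl on an oxygen on an aromatic ring). Within the data shown here, the only measured step, from pentyl to benzyloxy, was within the scatter, and no measured step touches the group on that oxygen, so the expectation for compound 3 rests on little. A step of a 1.6-fold higher number from compound 2 to compound 3 (0.21 log units; within the scatter) is expected, and compound 3 is estimated at 45 nM with a range from 15 nM to 150 nM.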

Compound 3, half-maximal inhibitory concentration: 9.4 nM
Beside the measured number, compound 3's estimate is 4.8-fold (0.68 log units) above it; the whole stated range lies above it.
By their numbers in this assay, from the lowest: compound 3; then compounds 1 and 2 (each within the scatter of the next).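

Putting tert-butyl in place of benzyl on the oxygen gives a 3.0-fold lower number from compound 2 to compound 3 (0.47 log units; beyond the scatter) in this assay and so shows that the group on that oxygen can move the number, which the earlier pair, within the scatter of each other, did not reveal. Tert-butoxy in place of pentyl gives a 2.9-fold lower number from compound 1 to compound 3 (0.46 log units; beyond the scatter) and so also separates compound 3 from compound 1. Nothing measured here explains these steps. From the compounds shown here alone, whether methyl or isopropyl on that oxygen would match tert-butyl remains open. So does whether an amine in place of the oxygen would hold the gain.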